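Amide substituent change on the shared core: solubility notes

The compounds below may be only part of what the source reports. "The series", "measured", "known", "first", "only" and "open" are said of these compounds alone.

Measured so far:
compound 1 `CNC(=O)c1cc(C(=O)N[C@H]2[C@@H]3COC[C@@H]32)cc2c1OC[C@H]2c1ccccc1`: >= 165 ug/mL
compound 2 `CNC(=O)c1cc(C(=O)N[C@H]2[C@@H]3COC[C@@H]32)cc2c1OC[C@H]2c1ccc(F)cc1`: >= 176 ug/mL

In a physicochemical assay for solubility (a lower number here means a less soluble compound, a higher number a more soluble compound), compound 1 reports only a limit, >= 165 ug/mL (the limit of >= 165 ug/mL in this assay, at which 1 of the 2 values shown sits). Compound 2 likewise reports only a limit, >= 176 ug/mL (the limit of >= 176 ug/mL in this assay, at which 1 of the 2 values shown sits). Among the compounds with values here, the single measured step, a step that the two limits leave unreadable from compound 1 to compound 2, is thus of no readable size. Compound 3 `CNC(=O)c1cc(C(=O)NC2CC2)cc2c1OC[C@H]2c1ccc(F)cc1` differs from compound 2 by a group of 3 heavy atoms (3 carbon; one three-membered non-aromatic ring of carbon only) in place of a group of 6 heavy atoms (5 carbon, 1 oxygen; one three-membered non-aromatic ring of carbon only, one five-membered non-aromatic ring with 1 hetero atom), on an amide-type nitrogen. Within the data shown here, no measured step bears on this change, so the expected size of an at least 1.2-fold lower number from compound 2 to compound 3 (0.09 log units; that floor lies within the scatter) is uncertain and may be none beyond the scatter. Compound 3 is estimated at 140 ug/mL, within 50 ug/mL to 300 ug/mL.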

Compound 3, solubility: 40 ug/mL
Compound 3: middle estimate off by 3.5-fold (0.54 log units), on the high side, and the stated range ends above it.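

On the amide-type nitrogen, the substituent makes a readable difference in this assay: cyclopropyl in place of the group of 6 heavy atoms gives an at least 4.4-fold lower number from compound 2 to compound 3 (0.64 log units; beyond the scatter). This is the only readable step shown, as the fluoro change could not be read. Its size is a floor, as compound 2 reports only a limit: the limit of >= 176 ug/mL in this assay, at which 1 of the 3 values shown sits.

Which part of the departing group carries this difference stays open. Also open, as far as these compounds go, is how a hydroxyethyl chain or a carboxylic acid on the same nitrogen would read in this assay.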